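The compounds below may be only part of what the source reports. "The series", "measured", "known", "first", "only" and "open" are said of these compounds alone.

Measured in a functional assay on HT-29 cells (Homo sapiens) for inhibition, read by sulforhodamine B assay, with a stated time of 48 h; on this read-out lower numbers stand for stronger inhibition of growth and higher numbers for weaker inhibition of growth:
- compound 1 `c1ccc(-c2ccc(NC3=NCCO3)cc2)cc1`: 5800 nM
- compound 2 `c1ccc(Oc2ccc(NC3=NCCO3)cc2)cc1`: 2000 nM
- compound 3 `c1ccc(COc2ccc(NC3=NCCO3)cc2)cc1`: 10300 nM

Compound 1 stands within the scatter of compound 3, so these two cannot be ranked. Compound 2 has a lower number than compound 1, and that gap lies beyond the scatter.

The next compound is compound 4 `Cc1ccc(NC2=NCCO2)cc1`, which has methyl in place of phenyl on an aromatic carbon. Among the compounds with values here, no pair of measured compounds differs in one place only, so no measured step guides this change. All of compound 1, compound 2 and compound 3 keep a phenyl ring on the far side of the shared core, and none shows what a lone methyl does in this assay. The expectation is therefore a loose extrapolation, with weaker inhibition of growth as the more likely direction.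

The expected step is a 2.6-fold higher number from compound 1 to compound 4 (0.41 log units; beyond the scatter), towards a higher number.

For compound 4 the estimated value is 15000 nM, with an expected range of 5000 nM to 45000 nM.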

Compound 4, concentration for 50% growth inhibition: 13000 nM
For compound 4 the middle estimate is 1.2-fold (0.06 log units) above the measured one, and the stated range covers the measured number.
By their numbers in this assay, from the lowest: compound 2; then compounds 1, 3 and 4 (each within the scatter of the next, the first and the last beyond it).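

In this assay, within the data shown here, the replacement of phenyl by methyl on this aromatic carbon gives a 2.2-fold higher number from compound 1 to compound 4 (0.35 log units; beyond the scatter), the first comparison in which only one place differs. The step is modest and beyond the scatter, so the six-membered aromatic ring at this position contributes to growth inhibition, yet it is not essential: compound 4 , which has no second ring, still gives a measurable 13000 nM in this read-out. No measured property of these compounds bears on the step, and its origin remains unexplained.

A single pair cannot show whether a cyclohexyl ring here would read like phenyl or like methyl. As far as these compounds go, the effects at this position of an amine, a carboxylic acid or a longer alkyl chain also remain open.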